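One Aryl Swap and Expected Tolerability in Liver Cells

A few compounds are considered here, and "the series" means these few. Any claim that something is new, unique, unknown or untested is made for them only; others in the source may bear on it.

Compound 1 `Clc1ccc(C(Oc2ccc3cc(Br)ccc3c2)c2cnc(NCC3CCCCC3)s2)cc1`, compound 2 `CCOC(=O)CCCNc1ncc(C(Oc2ccc3cc(Br)ccc3c2)c2ccc(Cl)cc2)s1` and compound 3 `O=C(Nc1ncc(C(Oc2ccc3cc(Br)ccc3c2)c2ccc(Cl)cc2)s1)c1ccc(Br)cc1` were all examined in an ADME assay on HepG2 2.2.15 cells (Homo sapiens) for cytotoxicity; a higher number here means that more compound is tolerated, a lower number that less compound is tolerated. In this assay compound 1 is recorded as "not toxic" (no number reported), and compound 2 likewise as "not toxic" (no number reported), without a number for either. For compound 3 the assay reports only a limit, > 50000 nM, which is the limit of > 50000 nM in this assay, at which 1 of the 3 values shown sits. Compound 3 therefore stands at the edge of what this assay can resolve, with no number that would set it against the other two. Compound 4 `O=C(Nc1ncc(C(Oc2ccc3cc(Br)ccc3c2)c2ccc(Cl)cc2)s1)c1ccc(F)cc1Br` carries 2-bromo-4-fluorophenyl in place of 4-bromophenyl on a carbonyl carbon, that is 2-bromo-4-fluorophenyl in place of 4-bromophenyl on a carbonyl carbon. Among the measured compounds shown here, no step between measured compounds is available to size this change, and no shift beyond the scatter is expected in this assay. The step that the limit leaves unreadable from compound 3 to compound 4 is expected to be flat. Compound 4 is expected to give 60000 nM in this assay, between 30000 nM and 150000 nM, most likely again reported only as a limit.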

Compound 4, half-maximal cytotoxic concentration: > 50000 nM
Compound 4: no number, only a limit; the forecaster's own chance of this, stated with the estimate: 80%; the middle value is on the limit's open side.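

In this assay compound 4 gives only a limit, > 50000 nM. With compound 3 also recorded only as a limit, no step can be read between compound 3 and compound 4. The compounds shown leave open at what concentration, if any, each becomes toxic to these cells.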